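A Halogenated Phenyl Ether Swap on a Shared Core

The compounds below may be only part of what the source reports. "The series", "measured", "known", "first", "only" and "open" are said of these compounds alone.

Four compounds share one core and differ only in the aromatic group at the far end of a short ether chain. Compound 1 `NC1=NC2(CCOCC2)N(OCCCOc2ccccc2Cl)C(N)=N1` carries a chlorophenyl group there; compound 2 `NC1=NC2(CCOCC2)N(OCCCOc2ccc(F)cc2)C(N)=N1` a fluorophenyl group; compound 3 `NC1=NC2(CCOCC2)N(OCCCOc2cc(Cl)c(Cl)cc2Cl)C(N)=N1` a trichlorophenyl group; and compound 4 `NC1=NC2(CCOCC2)N(OCCCOc2cccc(Br)c2)C(N)=N1` a bromophenyl group. In an assay on isolated protein for inhibition of Dihydrofolate reductase (Homo sapiens), read by spectrophotometry, using NADPH, with stated times of 5 s and 6 min, tested at 50 uM (a higher number here means a stronger effect of the compound at the concentration tested, a lower number a weaker effect), compound 1 gives 88.2%. For compound 2 the outcome in this assay is "not determined" (no result reported). For compound 3 the outcome in this assay is likewise "not determined" (no result reported), so compound 3 stands without a number of its own, and a second compound in the set also lacks one. The change from compound 3 to compound 4 is 3-bromophenyl in place of 2,4,5-trichlorophenyl on an oxygen on a saturated carbon. Going by the values given here, with no measured step to lean on, the expectation rests on compound 1 alone, whose 88.2% shows that a single halogen on the phenyl ether is compatible with strong inhibition; for compound 4 no step beyond the scatter is expected relative to that level, though a modest drop is possible. Compound 4 is therefore estimated to give 78% in this assay, within a range from 50% to 95%.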

Compound 4, a percentage reported as inhibition, at one concentration (the size of the read-out at that concentration, not a potency): 85.8%
Compound 4: middle estimate off by 7.8 percentage points, on the low side, within the range that was stated.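

The new result gives this set its first readable step: in this assay, a number 2.4 percentage points lower from compound 1 to compound 4 (within the scatter). Compound 1 and compound 4 therefore cannot be told apart in this read-out, even though 3-bromophenyl replaces 2-chlorophenyl on the oxygen and both the halogen and the numbering in the group's name differ. A second phenyl ether carrying one halogen thus reads at a level similar to that of compound 1, so strong inhibition at the tested concentration is not confined to the 2-chlorophenyl group; nothing here explains why the two groups read alike.

Steps involving compound 2 or compound 3 cannot be read, so the fluorophenyl and 2,4,5-trichlorophenyl groups add nothing to this comparison. Still open, as far as these compounds go, is how the read-out would respond to an amine or a carboxylic acid on the ring, or to a longer chain in place of the short ether chain. The read-out gives the size of the effect at one concentration only, and at other concentrations the effect of compound 1 could still be stronger or weaker than that of compound 4.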